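Prenyl removal on two related polycyclic cores

This account rests on a few compounds, and the source may have more. Where it says the series, first, only, none or still open, it means among the compounds named here.

Measured compounds: in a functional assay on HeLa cells (Homo sapiens) for inhibition (a lower number here means a stronger inhibitor, a higher number a weaker inhibitor), compound 1 `CC(C)=CCC/C(C)=C/C[C@@H]1C[C@]2(CC=C(C)C)C(=O)[C@@](CC=C(C)C)(C(=O)C(C(=O)c3ccc(O)c(O)c3)=C2O)C1(C)C` gives > 20 ug/mL, a limit of the assay. Compound 2 `CC(C)=CCC/C(C)=C/C[C@@H]1C[C@@]2(C/C=C(\C)CCC=C(C)C)C(=O)CC(=O)[C@](CC=C(C)C)(C2=O)C1(C)C` gives > 20 ug/mL in this assay, again a limit. Compound 3 `CC(C)=CCC/C(C)=C/C[C@@H]1C[C@]2(C/C=C(\C)CCC=C(C)C)C(=O)[C@@](CC=C(C)C)(C(=O)C(C(=O)c3ccc(O)c(O)c3)=C2O)C1(C)C` gives 8.09 ug/mL in this assay.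

Compound 3 and compound 1 differ by hydrogen in place of 3-methylbut-2-en-1-yl on a saturated chain carbon bound to a double-bonded chain carbon, and the step of an at least 2.4-fold higher number from compound 3 to compound 1 (0.39 log units; beyond the scatter). The cores of compound 2 and compound 3 differ in more than one place; that difference is not broken down here. Compound 4 `CC(C)=CCC/C(C)=C/C[C@@H]1C[C@@]2(CC=C(C)C)C(=O)CC(=O)[C@](CC=C(C)C)(C2=O)C1(C)C` is not yet measured and differs from compound 2 by hydrogen in place of 3-methylbut-2-en-1-yl on a saturated chain carbon bound to a double-bonded chain carbon, the same kind of change. Two of the three values sit at the limit of > 20 ug/mL in this assay, at which 2 of the 3 values shown sit. The step from compound 2 to compound 4 is expected to be a step that the limit leaves unreadable from compound 2 to compound 4, resting on an at least 2.4-fold higher number from compound 3 to compound 1 (0.39 log units; beyond the scatter) and on compound 2 already sitting at a limit. Compound 4 is therefore expected at 45 ug/mL, between 20 ug/mL and 120 ug/mL, most likely reported only as a limit.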

Compound 4, half-maximal inhibitory concentration: 9.69 ug/mL
Compound 4: the middle estimate sits 4.6-fold (0.67 log units) above what was measured; the measured number lies below the stated range.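

In this assay, removing the 3-methylbut-2-en-1-yl group gives an at least 2.0-fold lower number from compound 2 to compound 4 (0.31 log units; beyond the scatter), so the change does not carry from one core to the other with the same direction: the same change on two cores in this assay, an at least 2.4-fold higher number (0.39 log units; beyond the scatter) from compound 3 to compound 1 and an at least 2.0-fold lower number (0.31 log units; beyond the scatter) from compound 2 to compound 4, at least 5.1-fold (0.70 log units) apart, beyond the scatter of two such steps
Each step starts or ends at a limit, so only a minimum size is known for either: the limit of > 20 ug/mL in this assay, at which 2 of the 4 values shown sit.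
The cores differ in more than one place, and these compounds do not show which of those differences goes with the opposite directions.

Still open, going by these compounds, is how other groups at this place, such as a longer chain or a carboxylic acid, would read in this assay on each core. Also open, on these data alone, is whether the opposite directions would persist with those groups.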